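Replacing a Bromophenyl with a Dimethylphenyl on the Core

The source may report more compounds than this note shows. Statements on the series, on what has been measured and on what is new or still open speak of the compounds shown alone.

Measured compounds:
Compound 1, `CCC1=C(O)c2c(oc(-c3ccc(Br)cc3)cc2=O)C(CC)(CC)C1=O`, in a functional assay on KB cells (Homo sapiens) for antiproliferative activity, read by sulforhodamine B assay, with a stated time of 3 days (on this read-out lower numbers stand for an effect already at smaller amounts and higher numbers for an effect only at larger amounts of compound), gives > 48.1 uM, which is a limit of the assay rather than a number.
Compound 2, `CCC1=C(O)c2c(oc(-c3ccc(CBr)cc3)cc2=O)C(CC)(CC)C1=O`, in this assay gives > 46.5 uM, also a limit.
Compound 3, `CCC1=C(O)c2c(oc(-c3ccc(OC)cc3C)cc2=O)C(CC)(CC)C1=O`, in this assay gives 20.9 uM.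

As far as these compounds go, compound 1 therefore stands only at a limit, and its true number is unknown; compound 2 is in the same position, so compound 3 is the only one of the three with a measured number. The change to compound 4, `CCC1=C(O)c2c(oc(-c3cccc(C)c3C)cc2=O)C(CC)(CC)C1=O`, is 2,3-dimethylphenyl in place of 4-bromophenyl on an aromatic carbon.

The measured step closest in kind is an at least 2.3-fold lower number from compound 1 to compound 3 (0.36 log units; beyond the scatter), in which a phenyl carrying a methyl group replaced the 4-bromophenyl and brought the number under the limit. an at least 2.2-fold lower number from compound 2 to compound 3 (0.34 log units; beyond the scatter) points the same way. a step that the two limits leave unreadable from compound 1 to compound 2, so it offers nothing on size. Since compound 4 carries two methyl groups but no methoxy group, a step toward a lower number is expected, though smaller than that of compound 3 and possibly still at the limit. Compound 4 is thus estimated at 30 uM, within 12 uM to 60 uM, and the expected step is an at least 1.6-fold lower number from compound 1 to compound 4 (0.20 log units; that floor lies within the scatter).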

Compound 4, concentration for half-maximal effect: 3.1 uM
The estimate for compound 4 lay 9.7-fold (0.99 log units) above the measured number, and the stated range ends above it.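

At this aromatic carbon next to the ring oxygen, the choice of aryl group matters far more than compounds 1 to 3 could show: this assay gives an at least 15-fold lower number from compound 1 to compound 4 (1.19 log units; beyond the scatter), and likewise an at least 15-fold lower number from compound 2 to compound 4 (1.17 log units; beyond the scatter). For the compounds shown here, these two sizes are only floors, since the starting number of compound 1 is a limit and that of compound 2 is one too, so the real gaps may be larger: the limit of > 48.1 uM in this assay, at which 1 of the 4 values shown sits. The one step between two real numbers is a 6.7-fold lower number from compound 3 to compound 4 (0.83 log units; beyond the scatter), so the 2,3-dimethylphenyl group, which has no methoxy group, also clearly outdoes the 4-methoxy-2-methylphenyl group, the only aryl group in the earlier compounds to give a measured number.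

Which of the two methyl groups carries the gain remains open, and nothing measured here says why this aryl group gives so much lower a number. Also open, as far as these compounds go, is whether the number would hold with an amine or a carboxylic acid in place of these methyl groups, or with a longer chain such as ethyl.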